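The compounds below may be only part of what the source reports. "The series", "measured", "known", "first", "only" and "open" are said of these compounds alone.

Compound 1 `COc1ccc(-c2cnc(NC(=O)c3ccc(F)cc3)n2C)cc1` was examined in an ADME assay on microsomes from liver (Mus musculus) for metabolic stability (on this read-out higher numbers stand for fast clearance and lower numbers for slow clearance), where compound 1 gives 396 uL/min. Of the two numbers in hand this is the highest; the nearest is compound 2 `Cn1c(-c2cccc(Cl)c2)cnc1NC(=O)c1ncc[nH]1`, which in this assay gives 21 uL/min, a gap that lies beyond the scatter of repeated measurements. Compound 3 `COc1ccc(-c2cnc(NC(=O)c3ncc[nH]3)n2C)cc1` has not yet been measured in this assay. It differs from compound 1 in one place: 1H-imidazol-2-yl in place of 4-fluorophenyl on a carbonyl carbon. Within the data shown here, no measured pair in this set shows this exact change on its own, so the size of the step can only be anticipated. Compound 3 is expected to move downward, toward slower clearance, with an estimated step of an 8.8-fold lower number from compound 1 to compound 3 (0.94 log units; beyond the scatter), a change well beyond the scatter; this expectation leans on compound 2, whose value of 21 uL/min shows that a slow-clearance number is reachable within this series. For compound 3 the estimate in this assay is 45 uL/min, with a range from 15 uL/min to 140 uL/min.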

Compound 3, intrinsic clearance in a liver preparation (reported as CLH), per the amount of preparation that the assay uses: 511 uL/min
For compound 3 the middle estimate is 11-fold (1.06 log units) below the measured one; measured number outside the range, above it.
By their numbers in this assay, from the lowest: compound 2; then compounds 1 and 3 (each within the scatter of the next).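

In this assay, putting 1H-imidazol-2-yl in place of 4-fluorophenyl on the carbonyl carbon gives a 1.3-fold higher number from compound 1 to compound 3 (0.11 log units; within the scatter), so on the core of compound 1 this exchange of rings leaves the two compounds indistinguishable in clearance. Among these compounds, the 1H-imidazol-2-yl amide alone therefore does not bring a low number: compound 2 carries it and gives 21 uL/min, whereas compound 3 carries it too and gives 511 uL/min, so the low value of compound 2 cannot be read as a property of that group alone, and the aryl group on the core, the one place where compound 2 and compound 3 differ, now stands out as the place to look. Nothing at hand accounts for this outcome in terms of mechanism.

On these data alone, what remains open is whether any other group on the carbonyl carbon, such as a pyridin-2-yl ring or a simple methyl, would shift the number on this core. As far as these compounds go, it is equally open whether exchanging the methoxy group on the aryl ring for a chlorine or a nitrile would by itself reproduce the value of compound 2, and whether that would hold with 4-fluorophenyl on the carbonyl carbon.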